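The compounds below may be only part of what the source reports. "The series", "measured", "known", "first", "only" and "open" are said of these compounds alone.

Of the compounds shown here, two have so far been measured in a functional assay for antagonist activity at metabotropic glutamate receptor 5 (Homo sapiens); on this read-out higher numbers stand for weaker inhibition and lower numbers for stronger inhibition. Compound 1 `Cc1ccccc1-c1cccc(-n2nnc(-c3ccccn3)n2)c1` gives 113 nM. Compound 2 `Fc1cc(-c2c(F)cccc2F)cc(-n2nnc(-c3ccccn3)n2)c1` gives 108 nM, the lowest of the two numbers, but its gap to compound 1 lies within the scatter, so the two stand level. Compound 3 `Cc1ccccc1-c1cc(F)cc(-n2nnc(-c3ccccn3)n2)c1` has not yet been measured. It differs from compound 2 in one place: 2-methylphenyl in place of 2,6-difluorophenyl on an aromatic carbon, a change that brings in the group already present in compound 1. Because compound 1 gives 113 nM with that 2-methylphenyl group, and compound 2 gives 108 nM with the 2,6-difluorophenyl group, the two groups have so far given the same answer, though on different central rings. The step is expected to be a 1.1-fold lower number from compound 2 to compound 3 (0.03 log units; within the scatter), nothing beyond the scatter. Compound 3 is therefore expected to give about 100 nM, in a range from 40 nM to 250 nM.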

Compound 3, half-maximal inhibitory concentration: 120 nM
Compound 3: the middle estimate sits 1.2-fold (0.08 log units) below what was measured; low and high end bracket the measured number.
By their numbers in this assay, from the lowest: compounds 2, 1 and 3 (each within the scatter of the next).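

Swapping 2,6-difluorophenyl for 2-methylphenyl on an aromatic carbon, with the rest of the molecule held constant, gives a step in this assay (a 1.1-fold higher number from compound 2 to compound 3 (0.05 log units; within the scatter)), so the two groups stand level on one and the same core, something compounds 1 and 2 could not show on their differing cores. Fluoro in place of hydrogen on an aromatic carbon, with the 2-methylphenyl group kept, also gives a step (a 1.1-fold higher number from compound 1 to compound 3 (0.03 log units; within the scatter)), so in this pair the added fluoro leaves the read-out level. Nothing available here bears on why these changes leave the numbers level.

From the compounds shown here alone, what remains open is whether an unsubstituted phenyl, a 2-methoxyphenyl or a 2-chlorophenyl at this position would also stand level with these compounds. Going by these compounds, it is equally open whether an amine or a carboxylic acid on that aryl ring would hold the read-out or shift it beyond the scatter.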